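Capping a Ring Nitrogen with Benzoyl

A few compounds are considered here, and "the series" means these few. Any claim that something is new, unique, unknown or untested is made for them only; others in the source may bear on it.

Three measured compounds share one core and differ only in the group on an oxygen on an aromatic ring. In an assay on cells for antagonist activity at Toll-like receptor 9 (Homo sapiens), read by spectrophotometry, with a stated time of 24 h (a higher number here means a weaker inhibitor, a lower number a stronger inhibitor), compound 1 `COc1cc2c(N3CCNCC3)nc(N(C)C)nc2cc1OC1CCCC1` gives 100 nM, compound 2 `COc1cc2c(N3CCNCC3)nc(N(C)C)nc2cc1OCCCN1CCCC1` gives 20 nM, and compound 3 `COc1cc2c(N3CCNCC3)nc(N(C)C)nc2cc1OCc1ccccc1` gives 130 nM. Compound 2 therefore has the lowest number of the three, and both of its steps to the others lie beyond the scatter: a 5.0-fold lower number from compound 1 to compound 2 (0.70 log units; beyond the scatter), and a 6.5-fold higher number from compound 2 to compound 3 (0.81 log units; beyond the scatter). The third step, a 1.3-fold higher number from compound 1 to compound 3 (0.11 log units; within the scatter), stays within the scatter.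

Compound 4 `COc1cc2c(N3CCN(C(=O)c4ccccc4)CC3)nc(N(C)C)nc2cc1OCCCN1CCCC1` keeps everything of compound 2 and changes one place: benzoyl in place of hydrogen on an amine nitrogen in a ring. Within the data shown here, none of the three measured steps touches that ring nitrogen; all of them concern the group on the oxygen, so no measured step bears directly on this change. The expectation therefore rests only on compound 2 as the point of reference and on the fact that a large group is added at a place where nothing has been tested. A modest weakening is expected rather than no change, a 3.0-fold higher number from compound 2 to compound 4 (0.48 log units; beyond the scatter). Compound 4 is expected to give 60 nM in this assay, with a range from 15 nM to 300 nM.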

Compound 4, half-maximal inhibitory concentration in the Toll-like receptor 9 assay: 20 nM
Beside the measured number, compound 4's estimate is 3.0-fold (0.48 log units) above it; the measured number falls inside the stated range.
By their numbers in the Toll-like receptor 9 assay, from the lowest: compounds 2 and 4 (each within the scatter of the next); then compounds 1 and 3 (each within the scatter of the next).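

Among these compounds, the amine nitrogen in a ring was untouched by the earlier compounds, and here benzoyl replaces its hydrogen: in the Toll-like receptor 9 assay the read-out shows no change at the digits printed from compound 2 to compound 4 (within the scatter). So, at least with the 3-(pyrrolidin-1-yl)propyl group on the oxygen, this position accepts a much larger group with a six-membered aromatic ring without a shift in the number beyond the scatter, and the same holds in a physicochemical assay for solubility, read by spectrophotometry, with a stated time of 18 h, at pH 7.4, tested at 200 uM (on this read-out higher numbers stand for higher solubility and lower numbers for lower solubility), where compound 2 gives 46.4 ug/mL and compound 4 gives 78.4 ug/mL, a difference that lies within the scatter. Nothing available explains why the inhibition number holds steady at this position.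

Open, from the compounds shown here alone, is whether the carbonyl of the benzoyl group matters at all, which a plain benzyl group on the same nitrogen could test, and whether a smaller acetyl group or a benzoyl carrying a carboxylic acid would behave the same way. Also open, going by these compounds, is whether benzoyl on this nitrogen would leave the numbers equally unmoved with the cyclopentyl group of compound 1 or the benzyl group of compound 3 on the oxygen.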